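Dichlorophenyl analogue in the U-937 cytotoxicity series

The source may hold more compounds than are shown below. What is called first, only, known or untested is meant among the compounds shown, and "the series" means these compounds.

Of the compounds shown here, three sharing one core have been measured in a functional assay on U-937 cells (Homo sapiens) for cytotoxicity, read by CCK-8 assay, with a stated time of 72 h; a lower number here means a stronger inhibitor, a higher number a weaker inhibitor. Compound 1 `C=CCn1c(=O)/c(=C\c2cccc(C)c2)[nH]c(=O)/c1=C\c1ccccc1OC` gives 5100 nM, compound 2 `C=CCn1c(=O)/c(=C\c2cc(F)ccc2C)[nH]c(=O)/c1=C\c1ccccc1OC` gives 1000 nM, and compound 3 `C=CCn1c(=O)/c(=C\c2ccccc2F)[nH]c(=O)/c1=C\c1ccccc1OC` gives 5500 nM. Compound 3 stands at the highest number of the three, though its distance from compound 1 is within the scatter, while the step of a 5.5-fold higher number from compound 2 to compound 3 (0.74 log units; beyond the scatter) is beyond it. The unmeasured compound 4 `C=CCn1c(=O)/c(=C\c2cccc(Cl)c2Cl)[nH]c(=O)/c1=C\c1ccccc1OC` differs from compound 3 as follows: 2,3-dichlorophenyl in place of 2-fluorophenyl on a double-bonded chain carbon bound to an aromatic carbon. The step of a 5.1-fold lower number from compound 1 to compound 2 (0.71 log units; beyond the scatter) and the step of a 5.5-fold higher number from compound 2 to compound 3 (0.74 log units; beyond the scatter) bear on this change, since in both the 5-fluoro-2-methylphenyl of compound 2 paired with the lowest number, whereas 3-methylphenyl and 2-fluorophenyl paired with the highest. Within the data shown here, because 1000 nM belongs to compound 2, the 2,3-dichlorophenyl of compound 4 is expected to bring a modest lower number, a 2.8-fold lower number from compound 3 to compound 4 (0.44 log units; beyond the scatter), though no dichloro example has been measured. Compound 4 is therefore estimated at 2000 nM, within the range 700 nM to 6000 nM.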

Compound 4, half-maximal inhibitory concentration: 500 nM
Estimate against measurement, compound 4: 4.0-fold (0.60 log units) above; the whole stated range lies above it.
By their numbers in this assay, from the lowest: compounds 4 and 2 (each within the scatter of the next); then compounds 1 and 3 (each within the scatter of the next).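

In this assay, the place on a double-bonded chain carbon bound to an aromatic carbon now shows large steps, where the earlier ones were modest at most: 2,3-dichlorophenyl gives an 11-fold lower number from compound 3 to compound 4 (1.04 log units; beyond the scatter) in place of 2-fluorophenyl and a 10-fold lower number from compound 1 to compound 4 (1.01 log units; beyond the scatter) in place of 3-methylphenyl. In place of 5-fluoro-2-methylphenyl, the same group gives a 2.0-fold lower number from compound 2 to compound 4 (0.30 log units; within the scatter), so the four compounds fall into two sets, compound 4 with compound 2 and compound 1 with compound 3. Nothing measured here accounts for this division.

As far as these compounds go, it remains open whether a single chlorine, a methoxy group or an amine on this phenyl ring would join the first set or the second. Also open, from the compounds shown here alone, is whether 2,3-dichlorophenyl would hold its standing with a different group elsewhere on the shared core.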